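This account rests on a few compounds, and the source may have more. Where it says the series, first, only, none or still open, it means among the compounds named here.

Working notes on the amidrazone thiosemicarbazide series. All three measured compounds were run in a functional assay on A-375 cells (Homo sapiens) for cytotoxicity, read by MTT assay, with a stated time of 72 h, tested at 3 uM; on this read-out lower numbers stand for less inhibition of growth and higher numbers for more inhibition of growth at the one concentration tested.

compound 1, `N/C(=N\NC(=S)N1CCCCCC1)c1ccccn1`: 78.6%
compound 2, `Cc1ccnc(/C(N)=N/NC(=S)N2CCCCCC2)c1`: 70%
compound 3, `Cc1cccc(/C(N)=N/NC(=S)N2CCCC2)n1`: 51.3%

Compound 3 stands lowest of the three in this assay; both compound 2, the nearest, and compound 1 lie beyond the scatter above it. Compound 2 and compound 1 differ by one change, (hydrogen in place of methyl on an aromatic carbon), and the step between them, a number 8.6 percentage points higher from compound 2 to compound 1 (within the scatter), stays within the scatter. Compound 4, `N/C(=N\NC(=S)N1CCCC1)c1ccccn1`, has not yet been measured in this assay. It differs from compound 3 by hydrogen in place of methyl on an aromatic carbon. This is the same kind of change as that from compound 2 to compound 1, not the same one: there the methyl sits opposite the ring nitrogen, here it sits next to the ring nitrogen. The difference between the core of compound 3 and the core of compound 2 is not broken down here. Among the measured compounds shown here, the only measured instance of this kind of change, a number 8.6 percentage points higher from compound 2 to compound 1 (within the scatter), stayed within the scatter, so a step of similar size, a number 6.7 percentage points higher from compound 3 to compound 4 (within the scatter), is expected. Compound 4 is accordingly estimated at 58%, likely between 42% and 74%.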

Compound 4, percent growth inhibition at one concentration: 80%
Compound 4: middle estimate off by 22 percentage points, on the low side, and the stated range ends below it.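

In this assay, hydrogen in place of methyl on an aromatic carbon now gives a number 28.7 percentage points higher from compound 3 to compound 4 (beyond the scatter), so the size of this step does not carry over from one core to the other: the same change on two cores in this assay, a number 8.6 percentage points higher (within the scatter) from compound 2 to compound 1 and a number 28.7 percentage points higher (beyond the scatter) from compound 3 to compound 4, 20.1 percentage points apart, beyond the scatter of two such steps

Both steps point upward, but only the newer one lies beyond the scatter, so a reliable gain from this change is seen on the core of compound 3 alone. The two pairs differ both in where the methyl sits and in the rest of the core, so they do not show which of these sets the size of the step, and two pairs give no rule for any further core.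

Only methyl and hydrogen are shown on the aromatic ring, so the outcome with a chloro, methoxy or amine group there remains open. All values also come from one concentration, leaving open whether these steps would hold across a full concentration range.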